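The source may hold more compounds than are shown below. What is called first, only, known or untested is meant among the compounds shown, and "the series" means these compounds.

Of the compounds shown here, three that share one core have been tested in an ADME assay on HEK293 cells (Homo sapiens) for inhibition, read by resazurin assay, with a stated time of 72 h; a higher number here means a weaker inhibitor, a lower number a stronger inhibitor. Compound 1 `CC(C)=CCC[C@H](C)[C@H]1c2cc(C(=O)NCc3ccccc3)c(OC(=O)C(C)(C)C)c(OC(=O)C(C)(C)C)c2[C@H](C)C[C@H]1OC(=O)C(C)(C)C` gives 40000 nM. Compound 2 `CC(C)=CCC[C@H](C)[C@H]1c2cc(C(=O)NCc3ccc(Br)cc3)c(OC(=O)C(C)(C)C)c(OC(=O)C(C)(C)C)c2[C@H](C)C[C@H]1OC(=O)C(C)(C)C` gives 40000 nM. Compound 3 `CC(C)=CCC[C@H](C)[C@H]1c2cc(C(=O)NCc3ccc(F)cc3)c(OC(=O)C(C)(C)C)c(OC(=O)C(C)(C)C)c2[C@H](C)C[C@H]1OC(=O)C(C)(C)C` gives 80000 nM. Compound 2 stands level with compound 1, and the two together hold the lowest numbers of the three; the step of no change at the digits printed from compound 1 to compound 2 (within the scatter) and the step of a 2.0-fold higher number from compound 2 to compound 3 (0.30 log units; within the scatter) both lie within the scatter, as does the step of a 2.0-fold higher number from compound 1 to compound 3 (0.30 log units; within the scatter).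

Compound 4 `CC(C)=CCC[C@H](C)[C@H]1c2cc(C(=O)NCCN(C)C)c(OC(=O)C(C)(C)C)c(OC(=O)C(C)(C)C)c2[C@H](C)C[C@H]1OC(=O)C(C)(C)C` has not yet been measured. It differs from compound 2 in one place: (dimethylamino)methyl in place of 4-bromophenyl on a saturated chain carbon bound to an amide-type nitrogen. Cut one bond further out, the 4-bromobenzyl becomes a 2-(dimethylamino)ethyl.

For the measured compounds named here, the only measured steps concern exchanges on an aromatic carbon, a different kind of change, and all of them lie within the scatter. Going by the values given here, no measured step exchanges a ring for a chain, so the expectation rests on the narrow spread of the three numbers. Compound 4 is therefore expected to show no change at the digits printed from compound 2 to compound 4 (within the scatter), a step not beyond the scatter. Compound 4 is estimated at 40000 nM, within a range from 15000 nM to 100000 nM.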

Compound 4, half-maximal inhibitory concentration: 14600 nM
Compound 4: the middle estimate sits 2.7-fold (0.44 log units) above what was measured; measured number outside the range, below it.
By their numbers in this assay, from the lowest: compound 4; then compounds 1, 2 and 3 (each within the scatter of the next).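

In this assay, putting (dimethylamino)methyl in place of the phenyl, 4-bromophenyl or 4-fluorophenyl on the saturated chain carbon bound to the amide-type nitrogen lowers the number each time (a 2.7-fold lower number from compound 1 to compound 4 (0.44 log units; beyond the scatter); a 2.7-fold lower number from compound 2 to compound 4 (0.44 log units; beyond the scatter); a 5.5-fold lower number from compound 3 to compound 4 (0.74 log units; beyond the scatter)). All three steps are modest but beyond the scatter, whereas the exchanges on the aromatic carbon among compounds 1, 2 and 3 all stayed within it, so this position does respond when the whole ring gives way to an amine-bearing chain. Nothing measured here accounts for the shift.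

The compounds shown cannot separate the loss of the ring from the arrival of the amine, which a plain butyl chain or a 2-methoxyethyl group at this position would help to tell apart. On these data alone, how the number responds to a longer chain, such as 3-(dimethylamino)propyl, also remains open.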